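Thiophen-3-yl gives way to pyridin-2-yl

The source may report more compounds than this note shows. Statements on the series, on what has been measured and on what is new or still open speak of the compounds shown alone.

In a physicochemical assay for solubility, in phosphate buffer, with a stated time of 18 h (a lower number here means a less soluble compound, a higher number a more soluble compound), compound 1 `Cc1nc(C(C)(C)C)nc2nc(N)c(C#N)c(N)c12` gives 37000 nM, compound 2 `CC(C)(C)c1nc(CCCCC#N)c2c(N)c(C#N)c(N)nc2n1` gives 16000 nM and compound 3 `CC(C)(C)c1nc(-c2ccsc2)c2c(N)c(C#N)c(N)nc2n1` gives 40000 nM. Compound 3 therefore stands level with compound 1 and apart from compound 2. Compound 4 `CC(C)(C)c1nc(-c2ccccn2)c2c(N)c(C#N)c(N)nc2n1` carries pyridin-2-yl in place of thiophen-3-yl on an aromatic carbon. For the measured compounds named here, no measured step swaps one aromatic ring for another. The nearest guides are changes at the same place, a 1.1-fold higher number from compound 1 to compound 3 (0.03 log units; within the scatter) and a 2.5-fold higher number from compound 2 to compound 3 (0.40 log units; beyond the scatter), alongside a 2.3-fold lower number from compound 1 to compound 2 (0.36 log units; beyond the scatter). Even the larger of these are only modest, so a small move is expected in this assay. The expected step is no change at the digits printed from compound 3 to compound 4 (within the scatter), which would be no change beyond the scatter. For compound 4 the estimate is 40000 nM, with an expected range of 16000 nM to 100000 nM.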

Compound 4, solubility: 87000 nM
Compound 4: middle estimate off by 2.2-fold (0.34 log units), on the low side; low and high end bracket the measured number.
By their numbers in this assay, from the lowest: compound 2; then compounds 1 and 3 (each within the scatter of the next); then compound 4.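

Pyridin-2-yl gives a 2.2-fold higher number from compound 3 to compound 4 (0.34 log units; beyond the scatter) in this assay, so exchanging one aromatic ring for another at this carbon moves the number beyond the scatter, which thiophen-3-yl in place of methyl did not do. Pyridin-2-yl also gives a 2.4-fold higher number from compound 1 to compound 4 (0.37 log units; beyond the scatter) against methyl and a 5.4-fold higher number from compound 2 to compound 4 (0.74 log units; beyond the scatter) against the nitrile-bearing chain, which leaves compound 4 highest of the four. Nothing measured here explains the rise.

The compounds shown leave open whether the ring nitrogen or the six-membered ring carries the rise, a question a plain phenyl ring at this carbon would address. From the compounds shown here alone, how a pyridine ring bearing an amine would read also remains open.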